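From 4-nitrophenyl to 3-chlorophenyl on a shared core

This account rests on a few compounds, and the source may have more. Where it says the series, first, only, none or still open, it means among the compounds named here.

In a functional assay on OVCAR-3 cells (Homo sapiens) for cytotoxicity, read by sulforhodamine B assay (on this read-out lower numbers stand for stronger inhibition of growth and higher numbers for weaker inhibition of growth), compound 1 `CC1=CC[C@@H]([C@@](C)(O)CCCC(C)(C)NC(=S)NN)CC1` gives 17200 nM, compound 2 `CC1=CC[C@@H]([C@@](C)(O)CCCC(C)(C)NC(=S)N/N=C\c2ccccc2)CC1` gives 6970 nM and compound 3 `CC1=CC[C@@H]([C@@](C)(O)CCCC(C)(C)NC(=S)N/N=C\c2ccc([N+](=O)[O-])cc2)CC1` gives 13400 nM. Compound 3 thus lies within the scatter of both other compounds. Compound 4 `CC1=CC[C@@H]([C@@](C)(O)CCCC(C)(C)NC(=S)N/N=C\c2cccc(Cl)c2)CC1` differs from it by 3-chlorophenyl in place of 4-nitrophenyl on a carbon with a double bond to nitrogen. Going by the values given here, two measured steps bear on this change. Gaining the aromatic ring gave a modest 2.5-fold lower number from compound 1 to compound 2 (0.39 log units; beyond the scatter), and adding the nitro group gave a 1.9-fold higher number from compound 2 to compound 3 (0.28 log units; within the scatter), which stays within the scatter. Among the compounds with values here, no chlorine-bearing compound has been measured. The expected step is therefore small, a 1.5-fold lower number from compound 3 to compound 4 (0.17 log units; within the scatter), and not beyond the scatter. For compound 4 the estimated value is 9000 nM, with an expected range of 4000 nM to 18000 nM.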

Compound 4, concentration for 50% growth inhibition: 8270 nM
Estimate against measurement, compound 4: 1.1-fold (0.04 log units) above; the measured number falls inside the stated range.
By their numbers in this assay, from the lowest: compounds 2, 4, 3 and 1 (each within the scatter of the next, the first and the last beyond it).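

In this assay, adding chloro to the aromatic ring (a 1.2-fold higher number from compound 2 to compound 4 (0.07 log units; within the scatter)) and exchanging 4-nitrophenyl for 3-chlorophenyl (a 1.6-fold lower number from compound 3 to compound 4 (0.21 log units; within the scatter)) both stay within the scatter. Attaching the 3-chlorophenyl group to the shared core gives a modest step beyond the scatter (a 2.1-fold lower number from compound 1 to compound 4 (0.32 log units; beyond the scatter)), like the phenyl group, whereas compound 3 stays within the scatter of compound 1. As far as these compounds go, whether an amine or a carboxylic acid on the aromatic ring would move the number beyond the scatter remains open. No evidence at hand accounts for these differences.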